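This account rests on a few compounds, and the source may have more. Where it says the series, first, only, none or still open, it means among the compounds named here.

Measured compounds:
Compound 1 `CCCC(=O)N(Cc1ccccc1)C1CCN(S(=O)(=O)c2c(C)cc(C)cc2C)CC1` — in a functional assay on DLD-1 cells (Homo sapiens) for antiproliferative activity, read by CellTiter-Glo, with a stated time of 72 h (a lower number here means a stronger inhibitor, a higher number a weaker inhibitor), compound 1 gives > 5000 nM, a limit of the assay rather than a number.
Compound 2 `Cc1cc(C)c(S(=O)(=O)N2CCC(N3CCC(C(C)C)CC3)CC2)c(C)c1` — in this assay compound 2 gives 0.3 nM.
Compound 3 `COc1ccc(-c2ccccc2S(=O)(=O)N2CCC(N3CCC(C)CC3)CC2)cc1` — in this assay compound 3 gives 1000 nM.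

Compound 2 holds the lowest of the two numbers shown, with compound 3 its nearest neighbour at a markedly higher value, a gap well beyond the scatter. Compound 4 `Cc1cc(C)c(S(=O)(=O)N2CCC(N3CCCCC3)CC2)c(C)c1` differs from compound 2 by hydrogen in place of isopropyl on a saturated ring carbon. Among the compounds with values here, no step between two measured compounds covers this change. Compound 4 is expected to be weaker, the step from a 33-fold higher number from compound 2 to compound 4 (1.52 log units; beyond the scatter) being estimated as a clear rise beyond the scatter. Compound 4 is therefore estimated at 10 nM, within a range from 1 nM to 300 nM.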

Compound 4, half-maximal inhibitory concentration: 2200 nM
Compound 4: middle estimate off by 220-fold (2.34 log units), on the low side; the whole stated range lies below it.
By their numbers in this assay, from the lowest: compound 2; then compound 3; then compound 4. At a limit, above all of these: compound 1.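

In this assay, replacing 4-isopropylpiperidin-1-yl with piperidin-1-yl gives a 7300-fold higher number from compound 2 to compound 4 (3.87 log units; beyond the scatter). Within the data shown here, this is the first comparison that changes one place alone, and it shows that the low number of compound 2 depends heavily on the isopropyl on this saturated ring carbon. Nothing measured here gives a cause for the step.

On these data alone, whether an ethyl, a cyclopropyl or a tert-butyl group at this place would give a number closer to that of compound 2 or of compound 4 stays open. So does the outcome with a hydroxyl group or an amine there.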